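The source may hold more compounds than are shown below. What is called first, only, known or untested is meant among the compounds shown, and "the series" means these compounds.

Measured so far in a functional assay on PC-3 cells (Homo sapiens) for inhibition, read by CellTiter-Glo, with a stated time of 72 h; on this read-out higher numbers stand for lower toxicity in this test and lower numbers for higher toxicity in this test:
Compound 1 `CC1=C(CC(=O)N2CCN(c3ccncc3)CC2)c2cc(F)ccc2/C1=C\c1ccc([S+](C)[O-])cc1`: 21900 nM
Compound 2 `CC1=C(CC(=O)NCCN2CCCC2)c2cc(F)ccc2/C1=C\c1nc2ccccc2s1`: 4940 nM
Compound 3 `CC1=C(CC(=O)N2CCN(c3ccncc3)CC2)c2cc(F)ccc2/C1=C\c1nc2ccccc2s1`: 12300 nM

Compound 1 sits at the high end of these numbers, level with compound 3 within the scatter, as a 1.8-fold lower number from compound 1 to compound 3 (0.25 log units; within the scatter) shows. The value of compound 2 is lower. That step involves a different swap, one that compound 4 `CC1=C(CC(=O)N(C)CCN(C)S(C)(=O)=O)c2cc(F)ccc2/C1=C\c1ccc([S+](C)[O-])cc1` does not make.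

Compound 4 keeps the rest of compound 1 and changes only the group on a carbonyl carbon: methyl(2-(methyl(methylsulfonyl)amino)ethyl)amino in place of 4-(pyridin-4-yl)piperazin-1-yl. The counted difference is methyl(2-(methyl(methylsulfonyl)amino)ethyl)amino in place of 4-(pyridin-4-yl)piperazin-1-yl on a carbonyl carbon.

Going by the values given here, the one measured swap at a carbonyl carbon is a 2.5-fold higher number from compound 2 to compound 3 (0.40 log units; beyond the scatter), a modest step that brings in the same 4-(pyridin-4-yl)piperazin-1-yl group that compound 4 gives up. It suggests that a change here can shift the number, but only by a small amount. Among the compounds with values here, no measured compound carries the entering chain, so the direction remains open, and no clear step beyond the scatter is expected in this assay. The expected change is a 1.1-fold higher number from compound 1 to compound 4 (0.06 log units; within the scatter). For compound 4 the estimated value is 25000 nM, with an expected range from 10000 nM to 60000 nM.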

Compound 4, half-maximal cytotoxic concentration: 42600 nM
Beside the measured number, compound 4's estimate is 1.7-fold (0.23 log units) below it, within the range that was stated.
By their numbers in this assay, from the lowest: compound 2; then compounds 3, 1 and 4 (each within the scatter of the next, the first and the last beyond it).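

In this assay, the carbonyl carbon of compound 1 takes an open chain with no ring, methyl(2-(methyl(methylsulfonyl)amino)ethyl)amino, in place of 4-(pyridin-4-yl)piperazin-1-yl, and the outcome is a 1.9-fold higher number from compound 1 to compound 4 (0.29 log units; within the scatter). Going by these compounds alone, at this place, then, both rings of the leaving group can give way to a chain without a step beyond the scatter, whereas the only earlier swap on a carbonyl carbon, a 2.5-fold higher number from compound 2 to compound 3 (0.40 log units; beyond the scatter), did pass the scatter, with a different outgoing group and a different group on the double-bonded chain carbon. No measurement at hand explains why these two swaps read differently.

On these data alone, whether the same chain would also leave the number level when the core carries the group that compound 3 has on its double-bonded chain carbon remains open. Also open, as far as these compounds go, is how the number would respond to a quite different group on the carbonyl carbon, such as a chain ending in a carboxylic acid or in a primary amine.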